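The source may hold more compounds than are shown below. What is called first, only, known or untested is meant among the compounds shown, and "the series" means these compounds.

In an ADME assay on L929 cells (Mus musculus) for cytotoxicity, read by resazurin assay, with a stated time of 48 h (a lower number here means that less compound is tolerated, a higher number that more compound is tolerated), compound 1 `C=Cn1c2ccc([N+](=O)[O-])cc2c(=O)n1Cc1ccccc1` gives 160000 nM. Compound 2 `COCCn1c2ccc([N+](=O)[O-])cc2c(=O)n1Cc1ccccc1` gives > 256000 nM, which is a limit of the assay and not a number. Among the measured compounds shown here, the only measured step that bears on what follows is an at least 1.6-fold higher number from compound 1 to compound 2 (0.20 log units; that floor lies within the scatter). Compound 3 `CCOCCCn1c2ccc([N+](=O)[O-])cc2c(=O)n1Cc1ccccc1` carries ethoxymethyl in place of methoxy on a saturated chain carbon, two bonds along the chain from an aromatic nitrogen. With so little to go on, no change beyond the scatter is expected in this assay. The expected step is an at least 1.0-fold lower number from compound 2 to compound 3 (0.01 log units; that floor lies within the scatter). The estimated value for compound 3 is 250000 nM, within an expected range from 120000 nM to 500000 nM.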

Compound 3, concentration lethal to 50% of the cells: 170000 nM
For compound 3 the middle estimate is 1.5-fold (0.17 log units) above the measured one, and the stated range covers the measured number.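

Compound 2 gives > 256000 nM, which is a limit of the assay and not a number. Ethoxymethyl in place of methoxy on this chain gives an at least 1.5-fold lower number from compound 2 to compound 3 (0.17 log units; that floor lies within the scatter), so only a floor is known for this change, not its true size. Swapping vinyl for 3-ethoxypropyl on the aromatic nitrogen gives a 1.1-fold higher number from compound 1 to compound 3 (0.03 log units; within the scatter), so this assay does not tell these two groups apart.

Going by these compounds, whether an amine or a carboxylic acid at the end of this chain would move the number beyond the scatter stays open. How far compound 2 truly lies from compound 3 also stays open: the limit of > 256000 nM in this assay, at which 1 of the 3 values shown sits.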